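Trifluoromethyl replaces dimethylamino: stability expected to recover

This account rests on a few compounds, and the source may have more. Where it says the series, first, only, none or still open, it means among the compounds named here.

Measured compounds:
compound 1, `CCc1ncncc1-c1nc2cc(F)c(F)cc2n1C1CC1` — 78%
compound 2, `CN(C)c1ncncc1-c1nc2cc(F)c(F)cc2n1C1CC1` — 6%

Of the compounds shown here, two sharing one core have been measured in an ADME assay on microsomes from liver (Macaca fascicularis) for metabolic stability, read by LC-MS, with a stated time of 65 min, tested at 1 uM; on this read-out higher numbers stand for a more stable compound and lower numbers for a less stable compound. Among the compounds with values here, compound 1 gives 78%, whereas compound 2 gives 6% and so stands lowest of the two numbers, with compound 1 as its only neighbour. Within the data shown here, the single measured step, a number 72 percentage points lower from compound 1 to compound 2 (beyond the scatter), is the only change recorded so far, and it concerns exactly the position now altered again.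

Compound 3, `Fc1cc2nc(-c3cncnc3C(F)(F)F)n(C3CC3)c2cc1F`, differs from compound 2 as follows: trifluoromethyl in place of dimethylamino on an aromatic carbon. The dimethylamino group that compound 2 carries is gone, and what remains is the shared core with a trifluoromethyl group at that aromatic carbon. Among the measured compounds shown here, no measured step speaks directly to trifluoromethyl at this position; the step from compound 1 to compound 2 is the only relevant evidence, and it was large.

Because compound 2 sits at 6% while compound 1 sits at 78%, compound 3 is expected to move upward by a number 69 percentage points higher from compound 2 to compound 3 (beyond the scatter). The estimate for compound 3 is therefore 75%, within a range from 45% to 97%.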

Compound 3, percent of the compound remaining: 99%
For compound 3 the middle estimate is 24 percentage points below the measured one; the whole stated range lies below it.
By their numbers in this assay, from the lowest: compound 2; then compound 1; then compound 3.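

In this assay the exchange of dimethylamino for trifluoromethyl gives a number 93 percentage points higher from compound 2 to compound 3 (beyond the scatter), which more than undoes the loss seen when dimethylamino took the place of ethyl on this aromatic carbon. The earlier pair showed only that a change at this position could lower the number; trifluoromethyl in place of ethyl now gives a number 21 percentage points higher from compound 1 to compound 3 (beyond the scatter), so the position can also move the read-out upward from the level set by ethyl, and ethyl is not the best of the three groups shown here. Nothing available on these compounds accounts for the order of the three groups.

The compounds shown leave open whether the high number is particular to trifluoromethyl or would also be reached with other groups on this carbon, such as a methoxy group, a nitrile or a chlorine atom. They also leave open whether the low number of compound 2 extends to other amines here, such as methylamino or morpholine.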